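Methyl for piperidin-4-yl on compound 2

A few compounds are considered here, and "the series" means these few. Any claim that something is new, unique, unknown or untested is made for them only; others in the source may bear on it.

Measured in a functional assay on MDA-MB-231 cells (Homo sapiens) for antiproliferative activity, read by MTT assay, with a stated time of 72 h; a higher number here means a weaker inhibitor, a lower number a stronger inhibitor:
- compound 1 `CC(Oc1nc(N)nc2ccc(-c3cnn(C4CCNCC4)c3)cc12)c1c(Cl)ccc(F)c1Cl` 7000 nM
- compound 2 `CC(Oc1ncnc2ccc(-c3cnn(C4CCNCC4)c3)cc12)c1c(Cl)ccc(F)c1Cl` 6770 nM
- compound 3 `COc1cccc(CNc2ncnc3ncc(-c4cnn(C)c4)cc23)c1` > 100000 nM (a limit)

Within the data shown here, only two of these values are numbers, and they sit level: a 1.0-fold lower number from compound 1 to compound 2 (0.01 log units; within the scatter). That step lies at another place in the molecule and does not bear on the change considered here.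

Compound 4 `CC(Oc1ncnc2ccc(-c3cnn(C)c3)cc12)c1c(Cl)ccc(F)c1Cl` differs as follows: methyl in place of piperidin-4-yl on an aromatic nitrogen. Among the measured compounds shown here, no measured step covers this change. Compound 3, which also bears 1-methyl-1H-pyrazol-4-yl but on another core, gives > 100000 nM as a limit, and this alone tilts the expectation upward. The step expected in this assay is a 2.2-fold higher number from compound 2 to compound 4 (0.35 log units; beyond the scatter), towards a higher number, though the support is thin. Compound 4 is estimated at 15000 nM, with 4000 nM to 60000 nM as the expected range.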

Compound 4, half-maximal inhibitory concentration: 30000 nM
The estimate for compound 4 lay 2.0-fold (0.30 log units) below the measured number; the measured number falls inside the stated range.
By their numbers in this assay, from the lowest: compounds 2 and 1 (each within the scatter of the next); then compound 4. At a limit, above all of these: compound 3.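

In this assay, replacing piperidin-4-yl on the aromatic nitrogen gives a step beyond the scatter: a 4.4-fold higher number from compound 2 to compound 4 (0.65 log units; beyond the scatter). The amino change elsewhere on the shared core gave no such separation: a 1.0-fold lower number from compound 1 to compound 2 (0.01 log units; within the scatter). Compound 3, on another core, bears the same 1-methyl-1H-pyrazol-4-yl group, and its value is a limit: the limit of > 100000 nM in this assay, at which 1 of the 4 values shown sits.

The compounds shown leave open whether the difference follows the ring nitrogen of piperidin-4-yl or its ring carbons. A cyclohexyl group or a 2-aminoethyl chain on the same aromatic nitrogen would separate the two.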